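The source may hold more compounds than are shown below. What is called first, only, known or untested is meant among the compounds shown, and "the series" means these compounds.

Compound 3 `CCOC/C=C/c1ccc(CN(C(=O)C2CCCCC2)c2cccc(/C=C/C(=O)OC)c2)cc1` gives 198000 nM in an assay on isolated protein with Bile acid receptor (Homo sapiens) as the target (a lower number here means that less compound is needed, a higher number that more compound is needed for the effect), the highest of the numbers in hand. Compound 1 `COC(=O)/C=C/c1cccc(N(Cc2ccc(-c3ccc(C(C)(C)C)cc3)cc2)C(=O)C2CCCCC2)c1` gives 132 nM in this assay, and the move from the 4-(tert-butyl)phenyl of compound 1 to the 3-ethoxyprop-1-en-1-yl of compound 3 read a 1500-fold higher number from compound 1 to compound 3 (3.18 log units; beyond the scatter). Compound 2 `COC(=O)/C=C/c1cccc(N(Cc2ccc(/C=C/C(=O)NC(C)(C)C)cc2)C(=O)C2CCCCC2)c1` is reported only as a limit in this assay, > 1000 nM. Because of the limit of > 1000 nM in this assay, at which 1 of the 3 values shown sits, the step that the limit leaves unreadable from compound 2 to compound 3 cannot be sized, and an at least 7.5-fold higher number from compound 1 to compound 2 (0.87 log units; beyond the scatter) shows only that the 2-((tert-butyl)carbamoyl)ethenyl also sits well away from compound 1. Compound 4 `COC(=O)/C=C/c1cccc(N(Cc2ccc(/C=C/c3ccc(F)cc3)cc2)C(=O)C2CCCCC2)c1` differs from compound 3 by 4-fluorophenyl in place of ethoxymethyl on a double-bonded chain carbon bound to a double-bonded chain carbon. That change restores an aromatic ring, whose loss in the step of a 1500-fold higher number from compound 1 to compound 3 (3.18 log units; beyond the scatter) carried the largest change seen among these compounds. For compound 4 a large drop in this assay, a 200-fold lower number from compound 3 to compound 4 (2.30 log units; beyond the scatter), is therefore expected. For compound 4 the estimate in this assay is 1000 nM, with a range from 150 nM to 20000 nM.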

Compound 4, half-maximal effective concentration: 185 nM
The estimate for compound 4 lay 5.4-fold (0.73 log units) above the measured number, within the range that was stated.
By their numbers in this assay, from the lowest: compounds 1 and 4 (each within the scatter of the next); then compound 3.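

In this assay, with everything else held constant, exchanging the ethoxymethyl for the 4-fluorophenyl on a double-bonded chain carbon bound to a double-bonded chain carbon gives a 1100-fold lower number from compound 3 to compound 4 (3.03 log units; beyond the scatter), so this place responds strongly to which of these two groups it carries. The comparison with the 4-(tert-butyl)phenyl gives a 1.4-fold higher number from compound 1 to compound 4 (0.15 log units; within the scatter), so no difference can be read between it and the 2-(4-fluorophenyl)ethenyl, and a directly attached second ring is not the only arrangement compatible with a number of this size. Compound 2 is held only as a limit, so an at least 5.4-fold lower number from compound 2 to compound 4 (0.73 log units; beyond the scatter) sets a floor for this exchange of the (tert-butyl)carbamoyl and no more: the limit of > 1000 nM in this assay, at which 1 of the 4 values shown sits.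

On these data alone, whether the fluorine contributes, or the ring alone suffices, stays open. A plain phenyl or a cyclohexyl at this place would begin to separate those readings.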